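Ring size of the acylamino group on the urea aryl

This account rests on a few compounds, and the source may have more. Where it says the series, first, only, none or still open, it means among the compounds named here.

Compound 3 `O=C(Nc1cccc(-c2nc(-c3ccc(NC(=O)c4cccnc4)cc3Cl)no2)c1)Nc1ccc(NC(=O)C2CCCC2)c(C(F)(F)F)c1` gives 300 nM in a functional assay on MDA-MB-231 cells (Homo sapiens) for antiproliferative activity, read by MTT assay, with a stated time of 72 h (on this read-out higher numbers stand for weaker inhibition and lower numbers for stronger inhibition), and stands lowest of the three measured numbers. Compound 1 `O=C(Nc1cccc(-c2nc(-c3ccc(NC(=O)c4cccnc4)cc3Cl)no2)c1)Nc1ccc(Cl)c(C(F)(F)F)c1` gives 1900 nM and compound 2 `COc1ccc(NC(=O)Nc2cccc(-c3nc(-c4ccc(NC(=O)c5cccnc5)cc4Cl)no3)c2)cc1C(F)(F)F` gives 1700 nM; the move a 1.1-fold lower number from compound 1 to compound 2 (0.05 log units; within the scatter) stays within the scatter, whereas a 6.3-fold lower number from compound 1 to compound 3 (0.80 log units; beyond the scatter) and a 5.7-fold lower number from compound 2 to compound 3 (0.75 log units; beyond the scatter) are both beyond it, so the (cyclopentylcarbonyl)amino group carries the only gain seen so far.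

Compound 4 `O=C(Nc1cccc(-c2nc(-c3ccc(NC(=O)c4cccnc4)cc3Cl)no2)c1)Nc1ccc(NC(=O)C2CC2)c(C(F)(F)F)c1` differs from compound 3 by cyclopropyl in place of cyclopentyl on a carbonyl carbon. For the measured compounds named here, no measured step changes the ring on that carbonyl carbon; the steps from compound 1 and from compound 2 to compound 3 only compare the acylamino group against chloro or methoxy and say nothing about ring size. The expectation is therefore that compound 4 keeps most of what compound 3 shows, with the step of a 1.5-fold higher number from compound 3 to compound 4 (0.18 log units; within the scatter) expected to be small, possibly within the scatter, and its direction uncertain. Compound 4 is estimated at 450 nM, with a range from 150 nM to 1400 nM.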

Compound 4, half-maximal inhibitory concentration: 200 nM
For compound 4 the middle estimate is 2.3-fold (0.35 log units) above the measured one, and the stated range covers the measured number.
By their numbers in this assay, from the lowest: compounds 4 and 3 (each within the scatter of the next); then compounds 2 and 1 (each within the scatter of the next).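

In this assay, cyclopropyl in place of cyclopentyl on a carbonyl carbon reads as a 1.5-fold lower number from compound 3 to compound 4 (0.18 log units; within the scatter), so these two rings are not told apart at this position. The acylamino gain also holds with cyclopropyl, with an 8.5-fold lower number from compound 2 to compound 4 (0.93 log units; beyond the scatter) and a 9.5-fold lower number from compound 1 to compound 4 (0.98 log units; beyond the scatter), so the gain seen earlier is not tied to the cyclopentyl ring alone. Nothing beyond these cell read-outs bears on this result.

The compounds shown leave open whether an acetyl group, a cyclohexylcarbonyl group or an acyl group carrying an amine would stay at this level on the same amide-type nitrogen. They also leave open whether the amide hydrogen matters, a question that a methyl group on that nitrogen would address.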